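Replacing iodo with ethoxycarbonyl in compound 1

The compounds below may be only part of what the source reports. "The series", "measured", "known", "first", "only" and "open" are said of these compounds alone.

Measured so far:
- compound 1 `FC(F)(F)c1cccc(NC(=S)Nc2ccc(I)cc2)c1`: 9500 nM
- compound 2 `CSCCCNC(=S)Nc1cccc(C(F)(F)F)c1`: > 100000 nM (a limit of the assay, not a number)

Within the data shown here, in an ADME assay on Vero 76 cells (Chlorocebus sabaeus) for cytotoxicity, read by crystal violet staining, with a stated time of 96 h (on this read-out lower numbers stand for higher toxicity in this test and higher numbers for lower toxicity in this test), compound 1 gives 9500 nM, the only exact number available so far. Compound 2 reads > 100000 nM, which is a limit of the assay.

Compound 3 `CCOC(=O)c1ccc(NC(=S)Nc2cccc(C(F)(F)F)c2)cc1` differs from compound 1 in one place, with ethoxycarbonyl in place of iodo on an aromatic carbon, para to a large group: ethoxycarbonyl in place of iodo on an aromatic carbon.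

Among the measured compounds shown here, only one measured step bears on this, and only loosely. The step of an at least 10-fold higher number from compound 1 to compound 2 (1.02 log units; beyond the scatter) is large and beyond the scatter, but there 3-(methylsulfanyl)propyl replaces the entire 4-iodophenyl. Compound 3 keeps the aromatic ring and exchanges only the iodo, so a much smaller change is expected than the step of an at least 10-fold higher number from compound 1 to compound 2 (1.02 log units; beyond the scatter). At most a slight lean towards a higher number seems likely, with no step beyond the scatter.

The expected step is a 1.5-fold higher number from compound 1 to compound 3 (0.17 log units; within the scatter).

For compound 3 the estimated value is 14000 nM, within an expected range of 4500 nM to 50000 nM.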

Compound 3, half-maximal cytotoxic concentration: 71000 nM
Compound 3: the middle estimate sits 5.1-fold (0.71 log units) below what was measured; the measured number lies above the stated range.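

The aromatic ring can stay and the number still rises: exchanging only the iodo for ethoxycarbonyl gives a 7.5-fold higher number from compound 1 to compound 3 (0.87 log units; beyond the scatter) in this assay. This shows that the group at this one place, para to a large group, matters in this test, something compound 2 could not show, since there the whole 4-iodophenyl was replaced at once. Compound 3 also gives an exact value close to the top of what the test reads, so the room for reading any further rise at this place is small: the limit of > 100000 nM in this assay, at which 1 of the 3 values shown sits.

Which part of the ethoxycarbonyl goes with the higher number stays open, since the exchange removes the iodo and brings in more heavy atoms, a double bond outside the aromatic ring and hydrogen-bond acceptors all together. As far as these compounds go, a carboxylic acid, an amide or a nitrile at this place would help to pull these apart, and it also remains open whether the step would hold with something other than the trifluoromethyl group on the other ring.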